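A few compounds are considered here, and "the series" means these few. Any claim that something is new, unique, unknown or untested is made for them only; others in the source may bear on it.

Working notes on the series. In a physicochemical assay for solubility, with a stated time of 18 h, at pH 7.4 (on this read-out higher numbers stand for higher solubility and lower numbers for lower solubility), compound 2 `CCC(CC)c1ccc2c(NCCCNCc3cccc(OC)c3O)ccnc2c1` stands lowest of the two numbers, giving 4200 nM; compound 1 `COc1ccccc1Oc1ccc2c(NCCCNCc3cccc(OC)c3O)ccnc2c1` gives 14500 nM. For the measured compounds named here, the single measured step, a 3.5-fold lower number from compound 1 to compound 2 (0.54 log units; beyond the scatter), is the only one that bears on the next change and is modest in size. Compound 3 `COc1cccc(CNCCCNc2ccnc3cc(-c4ccc(C(F)(F)F)cc4)ccc23)c1O` differs from compound 2 by 4-(trifluoromethyl)phenyl in place of pentan-3-yl on an aromatic carbon. As that step returned an aromatic ring to this position, a step of similar size, a 1.7-fold higher number from compound 2 to compound 3 (0.22 log units; within the scatter), is expected, with wide uncertainty. Compound 3 is therefore estimated at 7000 nM, with a range from 1800 nM to 28000 nM.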

Compound 3, solubility: 32000 nM
Compound 3: middle estimate off by 4.6-fold (0.66 log units), on the low side; measured number above the stated range.
By their numbers in this assay, from the lowest: compound 2; then compound 1; then compound 3.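

In this assay, the position now separates the two ring-bearing groups as well as ring from no ring: a 2.2-fold higher number from compound 1 to compound 3 (0.34 log units; beyond the scatter). With a 7.6-fold higher number from compound 2 to compound 3 (0.88 log units; beyond the scatter), 4-(trifluoromethyl)phenyl stands above both 2-methoxyphenoxy and pentan-3-yl, so all three groups at this aromatic carbon are now ordered beyond the scatter. Nothing measured here accounts for this order. The compounds shown leave open whether the rise belongs to the aromatic ring or to its trifluoromethyl, which a plain phenyl would separate. Going by these compounds, how a carboxylic acid or an amine would stand at this position also remains open.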